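The source may hold more compounds than are shown below. What is called first, only, known or untested is meant among the compounds shown, and "the series" means these compounds.

Measured in a functional assay on A549 cells (Homo sapiens) for cytotoxicity, read by colorimetric assay and MTT assay; on this read-out lower numbers stand for stronger inhibition and higher numbers for weaker inhibition:
- compound 1 `COc1cc(OC)c2cc(-c3ccccc3)c(O)nc2c1`: 10000 nM
- compound 2 `COc1ccc(-c2cc3c(OC)cc(OC)cc3n(CC#N)c2=O)cc1`: 10000 nM

In this assay compound 2, at 10000 nM, stands level with compound 1, and the two show no difference beyond the scatter. Neither compound therefore stands out from the other on this read-out.

Compound 3 `CCN(CC)C(=O)CCn1c(=O)c(-c2ccc(OC)cc2)cc2c(OC)cc(OC)cc21` has not yet been measured. It differs from compound 2 in one place: (diethylcarbamoyl)methyl in place of cyano on a saturated chain carbon bound to an aromatic nitrogen. In words, (diethylcarbamoyl)methyl stands in place of cyano on a saturated chain carbon bound to an aromatic nitrogen. Cut one bond further out, the same change reads cyanomethyl to 2-(diethylcarbamoyl)ethyl.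

Among the compounds with values here, no pair of measured compounds differs in one place only, so the data offer no measured step by which to size this change. The expectation in this assay is therefore for no step beyond the scatter, in either direction, and it rests on compound 2 at 10000 nM. The estimated step of no change at the digits printed from compound 2 to compound 3 (within the scatter) is expected to be small. For compound 3 the expected value is 10000 nM, within an estimated range of 3000 nM to 20000 nM.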

Compound 3, half-maximal inhibitory concentration: 10000 nM
Estimate against measurement, compound 3: no gap at the digits printed; the measured number falls inside the stated range.
By their numbers in this assay, from the lowest: compounds 1, 2 and 3 (each within the scatter of the next).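

In this assay, within the data shown here, swapping the cyano group for (diethylcarbamoyl)methyl gives no change at the digits printed from compound 2 to compound 3 (within the scatter), the first step that can be read as a change in one place. The group that enters holds 8 heavy atoms where the one that leaves holds 2, and a double bond outside aromatic rings replaces a triple bond, yet the read-out shows no difference beyond the scatter, so for this pair the number does not respond to this exchange at this position. Nothing available explains why the value holds across this change.

From the compounds shown here alone, it remains open whether any other group on this chain, such as a dimethylamino group, a carboxylic acid or a longer chain, would separate from the value shared by compound 2 and compound 3. Going by these compounds, it is equally open whether a change elsewhere on the shared core, such as hydroxyl or fluorine in place of a methoxy group, would move the read-out at all.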